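Removal of a tert-Butoxycarbonyl Group on Two Related Cores

A few compounds are considered here, and "the series" means these few. Any claim that something is new, unique, unknown or untested is made for them only; others in the source may bear on it.

Compound 1 `CC(C)[C@H](NC(=O)c1cc(Cl)ccc1OCCCCNC(=O)OC(C)(C)C)C(=O)Nc1ccc([N+](=O)[O-])cc1Cl` in a functional assay on MCF7 cells (Homo sapiens) for inhibition, read by MTT assay, with a stated time of 72 h (on this read-out lower numbers stand for stronger inhibition and higher numbers for weaker inhibition), gives > 10000 nM, a limit of the assay.
Compound 2 `CC(C)[C@H](NC(=O)c1cc(Cl)ccc1OCCCCN)C(=O)Nc1ccc([N+](=O)[O-])cc1Cl` in this assay gives > 10000 nM, also a limit.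
Compound 3 `CSCC[C@H](NC(=O)c1cc(Cl)ccc1OCCNC(=O)OC(C)(C)C)C(=O)Nc1ccc([N+](=O)[O-])cc1Cl` in this assay gives > 10000 nM, again a limit.

Compound 4 `CSCC[C@H](NC(=O)c1cc(Cl)ccc1OCCN)C(=O)Nc1ccc([N+](=O)[O-])cc1Cl` has not been measured. It differs from compound 3 by hydrogen in place of tert-butoxycarbonyl on an amine nitrogen. Compound 2 differs from compound 1 by hydrogen in place of tert-butoxycarbonyl on an amine nitrogen, the same change at the same place. The step that the two limits leave unreadable from compound 1 to compound 2 cannot be sized because of the limit of > 10000 nM in this assay, at which 3 of the 3 values shown sit. The difference between the core of compound 1 and the core of compound 3 is not broken down here. The measured instance of the change gives no readable size, and compound 3 itself sits at a limit, so compound 4 is expected to remain at or near that limit in this assay. The estimated step is a step that the limit leaves unreadable from compound 3 to compound 4. For compound 4 the estimate is 20000 nM, expected to lie between 8000 nM and 60000 nM.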

Compound 4, half-maximal inhibitory concentration: > 10000 nM
Compound 4 gave a limit, no number; the forecaster's own chance of this, stated with the estimate: 85%; the middle value lies beyond the limit too.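

Compound 4, like compound 3, gives only a limit in this assay, so no step from compound 3 to compound 4 can be read: the limit of > 10000 nM in this assay, at which 4 of the 4 values shown sit.

The compounds shown leave open whether hydrogen in place of tert-butoxycarbonyl changes inhibition on either core.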